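Styryl oxadiazinones against the flavin amine oxidase: a fluoro step

The source may report more compounds than this note shows. Statements on the series, on what has been measured and on what is new or still open speak of the compounds shown alone.

Measured so far, in an assay on cells for inhibition of Amine oxidase [flavin-containing] A (Homo sapiens), read by Amplex Red, with a stated time of 30 min; on this read-out higher numbers stand for weaker inhibition and lower numbers for stronger inhibition:
Compound 1, `O=C1COC(c2ccc(/N=C/c3ccc(Cl)cc3)cc2)=NN1`, reaches only the assay limit, > 100000 nM.
Compound 2, `N#CCCN1N=C(c2ccc(NC(=O)c3cccc(Cl)c3)cc2)OCC1=O`, likewise shows only the assay limit, > 100000 nM.
Compound 3, `O=C1COC(c2ccc(/C=C/c3ccccc3)cc2)=NN1`, again returns only the assay limit, > 100000 nM.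

Where compound 3 stands: every number so far is a limit rather than a measured value, and compound 3 sits with the others at that limit, as summarised by the limit of > 100000 nM in this assay, at which 3 of the 3 values shown sit. Going by the values given here, no compound in the set has yet given a genuine potency in this assay, so no step between measured compounds can be read.

The next compound, compound 4, `O=C1COC(c2ccc(/C=C/c3cccc(F)c3)cc2)=NN1`, differs from compound 3 by fluoro in place of hydrogen on an aromatic carbon. With three limits and no graded value behind it, there is nothing to anchor a direction for the change. The expected step is a step that the limit leaves unreadable from compound 3 to compound 4, which is to say none beyond the scatter, with the outcome most likely again a limit. Compound 4 is therefore expected to give 150000 nM, with a plausible range from 40000 nM to 600000 nM.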

Compound 4, half-maximal inhibitory concentration: > 100000 nM
Compound 4 was reported as a limit; the forecaster's own chance of this, stated with the estimate: 85%; the middle value is on the limit's open side.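

Compound 3 and compound 4 are both reported only as limits, so the fluoro step between them cannot be read: the limit of > 100000 nM in this assay, at which 4 of the 4 values shown sit.

The compounds shown leave open whether this series gives any graded potency, and which way fluoro in place of hydrogen would move it.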